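The source may hold more compounds than are shown below. What is called first, only, known or untested is meant among the compounds shown, and "the series" means these compounds.

In an ADME assay on microsomes from liver (Mus musculus) for metabolic stability, with a stated time of 10 min (on this read-out lower numbers stand for a less stable compound and higher numbers for a more stable compound), compound 1 `C[C@]1(C(=O)O)CC[C@H](C(=O)N2CC[C@](c3ccc(C(F)(C(F)(F)F)C(F)(F)F)cc3)(S(=O)(=O)c3ccc(F)cc3)C2)CC1` gives 93% and compound 2 `CO[C@]1(C(=O)N2CC[C@](c3ccc(C(F)(C(F)(F)F)C(F)(F)F)cc3)(S(=O)(=O)c3ccc(F)cc3)C2)CC[C@H](C(=O)O)CC1` gives 95% on the same core. The step of a number 2 percentage points higher from compound 1 to compound 2 (within the scatter) is the only measured one, and it concerns other groups on the carbonyl carbon. Compound 3 `COC(=O)[C@H]1CC[C@H](C(=O)N2CC[C@](c3ccc(C(F)(C(F)(F)F)C(F)(F)F)cc3)(S(=O)(=O)c3ccc(F)cc3)C2)CC1` offers no starting number: its result reads "not determined" (no result reported) in this assay and so gives no anchor. For the measured compounds named here, the move to compound 4 `O=C(N1CC[C@](c2ccc(C(F)(C(F)(F)F)C(F)(F)F)cc2)(S(=O)(=O)c2ccc(F)cc2)C1)C1(CO)CCS(=O)(=O)CC1` is the change 4-(hydroxymethyl)-1,1-dioxothian-4-yl in place of 4-(methoxycarbonyl)cyclohexyl on a carbonyl carbon and no measured compound carries the entering group. With no value for compound 3, no step size or direction can be expected, so compound 1 at 93% and compound 2 at 95% serve only as a loose guide. In this assay the estimated value for compound 4 is 85% with 62% to 98% as the expected range.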

Compound 4, percent of the compound remaining: 31%
For compound 4 the middle estimate is 54 percentage points above the measured one; the whole stated range lies above it.
By their numbers in this assay, from the lowest: compound 4; then compounds 1 and 2 (each within the scatter of the next).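

In this assay the change to 4-(hydroxymethyl)-1,1-dioxothian-4-yl on a carbonyl carbon gives a number 64 percentage points lower from compound 2 to compound 4 (beyond the scatter) and a number 62 percentage points lower from compound 1 to compound 4 (beyond the scatter) on the shared core. The earlier pair, which sat within the scatter of each other, gave no sign of this: the group at this position can decide the result, and the shared core alone does not ensure a high number. Nothing shown here explains the drop. Still open, from the compounds shown here alone, is which part of the entering group matters, the 1,1-dioxothiane ring or the hydroxymethyl; an aminomethyl group in place of the hydroxymethyl would test only the latter.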